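Halogen Removal on the Pyrazole-Side Ring: Compound 2 to Compound 4

The source may report more compounds than this note shows. Statements on the series, on what has been measured and on what is new or still open speak of the compounds shown alone.

Compound 2 `O=C(/C=C/c1ccc(Br)cc1)Nc1cc(-c2ccc(Br)cc2)[nH]n1` gives 1280 nM in a functional assay on B16-F10 cells (Mus musculus) for antiproliferative activity, read by MTT assay, with a stated time of 48 h (a lower number here means a stronger inhibitor, a higher number a weaker inhibitor), the highest of the three numbers, though compound 3 `O=C(/C=C/c1ccccc1)Nc1cc(-c2ccc(Br)cc2)[nH]n1` with 1270 nM and compound 1 `O=C(/C=C/c1ccc(Cl)cc1)Nc1cc(-c2ccc(Br)cc2)[nH]n1` with 1080 nM both lie within the scatter of it. Compound 4 `O=C(/C=C/c1ccc(Br)cc1)Nc1cc(-c2ccccc2)[nH]n1` differs from compound 2 by hydrogen in place of bromo on an aromatic carbon, read one bond further out as 4-bromophenyl to phenyl. The measured exchanges at a different aromatic carbon all stayed flat: a 1.0-fold lower number from compound 2 to compound 3 (0.00 log units; within the scatter), a 1.2-fold higher number from compound 1 to compound 3 (0.07 log units; within the scatter) and a 1.2-fold higher number from compound 1 to compound 2 (0.07 log units; within the scatter). Nothing shown suggests that removing bromo at this second site should behave differently, so no step beyond the scatter is expected here, that is a 1.0-fold lower number from compound 2 to compound 4 (0.01 log units; within the scatter). Compound 4 is therefore estimated at 1250 nM, with a range from 600 nM to 2600 nM.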

Compound 4, half-maximal inhibitory concentration: 1380 nM
For compound 4 the middle estimate is 1.1-fold (0.04 log units) below the measured one, and the stated range covers the measured number.
By their numbers in this assay, from the lowest: compounds 1, 3, 2 and 4 (each within the scatter of the next).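

The earlier compounds shown here varied only a different aromatic carbon, while the 4-bromophenyl group stayed fixed. Here the change to phenyl gives a 1.1-fold higher number from compound 2 to compound 4 (0.03 log units; within the scatter) in this assay and so extends the flat result to this second site, where bromo stood para to a large group. No measurement available here bears on this result. As far as these compounds go, whether an amine or a carboxylic acid in place of bromo at this position would give a step beyond the scatter remains open, as does the outcome with no halogen on either aromatic ring.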